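The compounds below may be only part of what the source reports. "The series", "measured", "known", "first", "only" and "open" are said of these compounds alone.

Compound 3 `O=C(/C=C\Nc1ccc(C(F)(F)F)cc1)c1cn(-c2ccccc2)nc1-c1ccc(Cl)cc1`, bearing trifluoromethyl on the anilino ring, returns in a functional assay on HT-29 cells (Homo sapiens) for antiproliferative activity, read by MTT assay, with a stated time of 48 h (on this read-out lower numbers stand for stronger inhibition and higher numbers for weaker inhibition), only a limit, > 50000 nM. Compound 1 `O=C(/C=C\Nc1ccc(F)cc1)c1cn(-c2ccccc2)nc1-c1ccc(Cl)cc1` is its fluoro counterpart; in this assay compound 1 likewise gives only a limit, > 50000 nM. Compound 2 `O=C(/C=C\Nc1ccc(Cl)cc1)c1cn(-c2ccccc2)nc1-c1ccc(Cl)cc1`, the chloro counterpart, gives 4650 nM in this assay. The readable steps are an at least 10-fold lower number from compound 1 to compound 2 (1.03 log units; beyond the scatter) and an at least 10-fold higher number from compound 2 to compound 3 (1.03 log units; beyond the scatter); the step that the two limits leave unreadable from compound 1 to compound 3 cannot be sized, since (the limit of > 50000 nM in this assay, at which 2 of the 3 values shown sit).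

Compound 4 `COc1cc(-c2nn(-c3ccccc3)cc2C(=O)/C=C\Nc2ccc(C(F)(F)F)cc2)cc(OC)c1OC` changes the other ring: 3,4,5-trimethoxyphenyl in place of 4-chlorophenyl on an aromatic carbon. Going by the values given here, all three measured steps concern the anilino substituent only; none of them touches the aryl group on the shared core, so no measured step gives a size or direction for this change in this assay. The estimate for compound 4 therefore rests on the limit of compound 3 alone and is broad: compound 4 is expected at 15000 nM, within 1500 nM to 100000 nM, which would be an expected step of an at least 3.3-fold lower number from compound 3 to compound 4 (0.52 log units; beyond the scatter).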

Compound 4, half-maximal inhibitory concentration: > 50000 nM
Compound 4 ended at the assay's limit; the forecaster's own chance of this, stated with the estimate: 40%; middle value at least 3.3-fold (0.52 log units) from the limit.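

Compound 4 gives only a limit in this assay, > 50000 nM. The step between compound 3 and compound 4 cannot be read because both compounds sit at that limit: the limit of > 50000 nM in this assay, at which 3 of the 4 values shown sit.

The compounds shown leave open how 3,4,5-trimethoxyphenyl in place of 4-chlorophenyl changes the number in this assay.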